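The compounds below may be only part of what the source reports. "The series", "measured", "known", "first", "only" and "open" are said of these compounds alone.

In a physicochemical assay for solubility, read by HPLC, in simulated intestinal fluid, with a stated time of 16 h, at pH 6.5 (a higher number here means a more soluble compound, a lower number a less soluble compound), compound 1 (`CC(=O)Nc1c(F)cc(C(=O)N[C@H]2CC[C@H](O)CC2)cc1O[C@@H](C)c1ccccc1`) gives 996 ug/mL and compound 2 (`CNC(=O)c1cc(C(=O)N[C@H]2CC[C@H](O)CC2)c([C@@H](C)c2cccc(OC)c2)o1`) gives 868 ug/mL. These two numbers lie within the scatter of each other, and the two compounds do not differ in one place only. Compound 3 (`CNC(=O)c1cc(C(=O)N[C@H]2CC[C@H](O)CC2)c([C@@H](C)c2ccc(C)cc2)o1`) departs from compound 2 in a single place: 4-methylphenyl in place of 3-methoxyphenyl on a saturated chain carbon bound to an aromatic carbon and a saturated chain carbon. For the measured compounds named here, no measured pair isolates this change, so any expectation in this assay is weakly supported: a small move toward a lower number, possibly none beyond the scatter. The expected step is a 1.3-fold lower number from compound 2 to compound 3 (0.13 log units; within the scatter). For compound 3 the estimated value is 650 ug/mL, with an expected range of 280 ug/mL to 1100 ug/mL.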

Compound 3, solubility: > 1000 ug/mL
Compound 3 gave a limit, no number (the forecaster's own chance of this, stated with the estimate: 10%); middle value at least 1.5-fold (0.18 log units) from the limit.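

In this assay compound 3 gives > 1000 ug/mL, a limit of the assay and not a number. Placing 4-methylphenyl in place of 3-methoxyphenyl on this saturated chain carbon gives an at least 1.1-fold higher number from compound 2 to compound 3 (0.06 log units; that floor lies within the scatter). This position therefore takes an aryl group with 0 hydrogen-bond acceptors with no fall in the number.

From the compounds shown here alone, whether an amine or a carboxylic acid on this aryl ring would shift the number remains open. The true size of the step also stays unread, because the reading stops at a ceiling: the limit of > 1000 ug/mL in this assay, at which 1 of the 3 values shown sits.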